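The source may hold more compounds than are shown below. What is called first, only, known or untested is meant among the compounds shown, and "the series" means these compounds.

Of the compounds shown here, two have been tested in an ADME assay on SK-MEL cells (Homo sapiens) for cytotoxicity, read by neutral red uptake, with a stated time of 48 h; on this read-out lower numbers stand for stronger inhibition and higher numbers for weaker inhibition. Compound 1 `O=c1sc2ccccc2n1CCCCCN1CCN(CCCCCn2c(=O)sc3ccccc32)CC1` gives 19800 nM, and compound 2 `O=c1sc2ccccc2n1CCCCCCN1CCN(CCn2c(=O)sc3ccccc32)CC1` gives 25000 nM. Compound 2 has the highest of the two numbers, yet its gap from compound 1 lies within the scatter, so neither can be called weaker than the other. Compound 3 `O=c1sc2ccccc2n1CCCCCCN1CCN(CCCCn2c(=O)sc3ccccc32)CC1` is not yet measured; it differs from compound 2 by a group of 12 heavy atoms (9 carbon, 1 nitrogen, 1 oxygen, 1 sulfur; one five-membered aromatic ring with 2 hetero atoms, one six-membered aromatic ring of carbon only) in place of a group of 10 heavy atoms (7 carbon, 1 nitrogen, 1 oxygen, 1 sulfur; one five-membered aromatic ring with 2 hetero atoms, one six-membered aromatic ring of carbon only), on a saturated chain carbon, two bonds along the chain from an amine nitrogen in a ring. Because compound 1 gives 19800 nM while compound 2 gives 25000 nM despite their different linkers, the expected step is a 1.1-fold lower number from compound 2 to compound 3 (0.06 log units; within the scatter), nothing beyond the scatter. Compound 3 is therefore estimated at 22000 nM, within a range of 9000 nM to 55000 nM.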

Compound 3, half-maximal inhibitory concentration: 14500 nM
For compound 3 the middle estimate is 1.5-fold (0.18 log units) above the measured one; measured number inside the range.
By their numbers in this assay, from the lowest: compounds 3, 1 and 2 (each within the scatter of the next).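

In this assay, placing the group of 12 heavy atoms where the group of 10 heavy atoms stood, on a saturated chain carbon, two bonds along the chain from an amine nitrogen in a ring, gives a 1.7-fold lower number from compound 2 to compound 3 (0.24 log units; within the scatter). Among the compounds shown here, this is the first pair differing in one place, and the change does not separate the two compounds on this read-out. No supporting measurement bears on this result. As far as these compounds go, a single step shows no trend, so it remains open whether a longer chain, or one carrying an amide, would give a difference beyond the scatter.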